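Replacing morpholin-4-yl with methylamino on a carbonyl carbon

A few compounds are considered here, and "the series" means these few. Any claim that something is new, unique, unknown or untested is made for them only; others in the source may bear on it.

In a functional assay on KB cells (Homo sapiens) for inhibition, read by sulforhodamine B assay, with a stated time of 72 h (a higher number here means a weaker inhibitor of growth, a lower number a stronger inhibitor of growth), compound 3 (`O=C(CCc1ccncc1-c1ccc2ccccc2c1)N1CCOCC1`) gives > 10000 nM as a limit of the assay and not as a number. Compound 1 (`CNC(=O)/C=C/c1ccncc1-c1ccc2ccccc2c1`) gives > 10000 nM as a limit too. Compound 2 (`NNC(=O)CCc1ccncc1-c1ccc2ccccc2c1`) likewise gives > 10000 nM as a limit. Compound 3 therefore has no exact number, and its only position is the one shared by the whole set: the limit of > 10000 nM in this assay, at which 3 of the 3 values shown sit, sums this up.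

The change to compound 4 (`CNC(=O)CCc1ccncc1-c1ccc2ccccc2c1`) is methylamino in place of morpholin-4-yl on a carbonyl carbon and, in words, puts methylamino in place of morpholin-4-yl on a carbonyl carbon. The closest measured change is a step that the two limits leave unreadable from compound 2 to compound 3 and it sits on that same carbonyl carbon. The other measured change is a step that the two limits leave unreadable from compound 1 to compound 2 and it offers no size either. Neither one supplies a size to carry over to compound 4, so the expectation is simply that nothing moves. In this assay the expected change is a step that the limit leaves unreadable from compound 3 to compound 4 and so none beyond the scatter in either direction. For compound 4 the estimated value is 15000 nM with an expected range from 6000 nM to 40000 nM and the most likely report is another limit.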

Compound 4, concentration for 50% growth inhibition: > 10000 nM
Compound 4: only a limit was reported (the forecaster's own chance of this, stated with the estimate: 90%); the middle value lies beyond the limit too.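

The steps to compound 4 from compound 1, compound 2 and compound 3 cannot be read, since each pair of values is a pair of limits and the set holds a single position: the limit of > 10000 nM in this assay, at which 4 of the 4 values shown sit.

The compounds shown leave open how strongly any of them inhibits growth, and which change, if any, would give a measurable value in this assay.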